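Trimming the ester chain: from compound 2 to compound 3

The compounds below may be only part of what the source reports. "The series", "measured", "known", "first", "only" and "open" are said of these compounds alone.

Two measured compounds share one core and differ only in the chain attached through the ester. Compound 1 `CCCCOC(=O)C(O)Cn1cnc2c(N)ncnc21` carries a butyl chain and compound 2 `CCCCCOC(=O)C(O)Cn1cnc2c(N)ncnc21` a pentyl chain. In a functional assay on Vero cells (Chlorocebus sabaeus) for cytotoxicity (a lower number here means that less compound is tolerated, a higher number that more compound is tolerated), compound 1 gives 200 ug/mL. In this assay compound 2 gives 200 ug/mL, so compound 2 stands level with compound 1 at the digits reported, and the step of no change at the digits printed from compound 1 to compound 2 (within the scatter) lies within the scatter.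

Compound 3 `CC(C)COC(=O)C(O)Cn1cnc2c(N)ncnc21` has not yet been measured in this assay. It differs from compound 2 by isopropyl in place of butyl on a saturated chain carbon bound to an oxygen next to a carbonyl group. Among the compounds with values here, the only measured step that bears on this change is the one between compound 1 and compound 2, which also alters nothing but the saturated chain on the carbon bound to an oxygen next to a carbonyl group, and that step produced no change beyond the scatter. Exchanging the chain once more is therefore expected to leave the read-out where it is, and no change at the digits printed from compound 2 to compound 3 (within the scatter) is expected to be no step beyond the scatter. Compound 3 is estimated to give 200 ug/mL in this assay, with a range from 100 ug/mL to 400 ug/mL.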

Compound 3, minimum cytotoxic concentration: > 400 ug/mL
Compound 3 ended at the assay's limit; the forecaster's own chance of this, stated with the estimate: 10%; at least 2.0-fold (0.30 log units) between middle value and limit.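

In this assay compound 3 gives > 400 ug/mL, which is a limit of the assay and not a number. Set against the two straight-chain esters, this reading amounts to an at least 2.0-fold higher number from compound 2 to compound 3 (0.30 log units; that floor lies within the scatter) and to an at least 2.0-fold higher number from compound 1 to compound 3 (0.30 log units; that floor lies within the scatter), so both steps are floors rather than measured sizes. At this place, on a saturated chain carbon bound to an oxygen next to a carbonyl group, adding one carbon to the straight chain gave no readable change, whereas the branched chain is the first exchange that may shift the read-out, though how far cannot be told: the limit of > 400 ug/mL in this assay, at which 1 of the 3 values shown sits.

The compounds shown leave open whether any real gap exists here at all and, if one does, whether it follows the branching itself or the shorter main chain, since the isobutyl ester differs from its straight-chain partners in both respects. They also leave open how a more heavily branched chain such as neopentyl, a longer chain such as hexyl, or a carboxylic acid in place of the ester would read in this assay.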